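A Dichlorophenyl Swap in a Level Series

This account rests on a few compounds, and the source may have more. Where it says the series, first, only, none or still open, it means among the compounds named here.

In a functional assay on HT-1080 cells (Homo sapiens) for cytotoxicity, read by MTT assay, with a stated time of 72 h (a lower number here means a stronger inhibitor, a higher number a weaker inhibitor), compound 1 `COc1cccc(/C=C2\CCC/C(=C\c3ccc(Cl)cc3)C2=O)c1OC` gives 11100 nM, compound 2 `COc1cccc(/C=C2\CCC/C(=C\c3ccccc3Br)C2=O)c1OC` gives 10800 nM and compound 3 `COc1ccc(/C=C2\CCC/C(=C\c3cccc(OC)c3OC)C2=O)cc1` gives 16300 nM. These numbers lie within the usual scatter of repeated measurements, so compound 3 stands level with the other two.

Compound 4 `COc1cccc(/C=C2\CCC/C(=C\c3ccc(Cl)c(Cl)c3)C2=O)c1OC` comes from compound 3 through a single structural change: 3,4-dichlorophenyl in place of 4-methoxyphenyl on a double-bonded chain carbon bound to a double-bonded ring carbon.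

Among the compounds with values here, two measured steps bear on this change. Putting 4-methoxyphenyl in place of 2-bromophenyl at the same place gave a 1.5-fold higher number from compound 2 to compound 3 (0.18 log units; within the scatter). Putting methoxy in place of chloro on an aromatic carbon gave a 1.5-fold higher number from compound 1 to compound 3 (0.17 log units; within the scatter). Within the data shown here, neither step goes beyond the scatter, and no measured compound yet carries 3,4-dichlorophenyl, so this group remains untested. No step beyond the scatter is therefore expected in this assay. Any slight lean would be toward a lower number, since the change removes methoxy and brings in chloro, the reverse of the direction of those two steps.

The expected result is a 1.6-fold lower number from compound 3 to compound 4 (0.21 log units; within the scatter). For compound 4 the estimated value is 10000 nM, with an expected range from 4500 nM to 21000 nM.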

Compound 4, half-maximal inhibitory concentration: 10800 nM
Beside the measured number, compound 4's estimate is 1.1-fold (0.03 log units) below it; low and high end bracket the measured number.
By their numbers in this assay, from the lowest: compounds 2, 4, 1 and 3 (each within the scatter of the next).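

In this assay, within the data shown here, the place on a double-bonded chain carbon bound to a double-bonded ring carbon now holds 3,4-dichlorophenyl, a group the earlier compounds did not carry, and the swap for 4-methoxyphenyl gives a 1.5-fold lower number from compound 3 to compound 4 (0.18 log units; within the scatter) while the swap for 2-bromophenyl gives no change at the digits printed from compound 2 to compound 4 (within the scatter) at this place. Among these compounds, the new compound also allows the first comparison in this set that adds a substituent without replacing one: chloro in place of hydrogen on an aromatic carbon gives a 1.0-fold lower number from compound 1 to compound 4 (0.01 log units; within the scatter) and so leaves the reading level with that of the compound carrying a lone chloro on its phenyl ring. All four compounds therefore stand level across these three phenyl groups, and no measurement here offers any explanation for how closely they agree.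

What the compounds leave open is whether any group at this place can move the number beyond the scatter, since each one shown is a phenyl ring bearing chloro, bromo or methoxy. A phenyl ring carrying an amine or a carboxylic acid, or a pyridine ring in the same place, would test whether this level reading holds for groups of a different kind.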